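Trimming a Long Alkyl Chain: Compound 3 to Compound 4

The source may hold more compounds than are shown below. What is called first, only, known or untested is meant among the compounds shown, and "the series" means these compounds.

Measured so far:
Compound 1 `CCCCCCCCCCCCCCCCCC/N=c1\nc(N)c2nc[nH]c2c(N)n1` gives 1430 nM in a functional assay on MDA-MB-231 cells (Homo sapiens) for antiproliferative activity, read by WST assay, with a stated time of 72 h; a lower number here means a stronger inhibitor, a higher number a weaker inhibitor.
Compound 2 `Nc1n/c(=N\CCCCc2ccccc2)nc(N)c2c1ncn2Cc1ccccc1` gives 16700 nM in this assay.
Compound 3 `CCCCCCCCCCCCCC/N=c1\nc(N)c2ncn(Cc3ccccc3)c2c(N)n1` gives 5850 nM in this assay.

Of these three numbers, compound 3 stands second highest. Its nearest neighbour is compound 2: the step of a 2.9-fold lower number from compound 2 to compound 3 (0.46 log units; beyond the scatter) moves the number downward, so the longer chain on the double-bonded nitrogen goes with a stronger inhibitor. Going by the values given here, compound 1, which carries an even longer chain and no benzyl group on its core, shows a lower number still, though no single-point step links it to compound 3.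

Compound 4 `CCCCCCCC/N=c1\nc(N)c2ncn(Cc3ccccc3)c2c(N)n1` differs from compound 3 in one place: hydrogen in place of hexyl on a saturated chain carbon, eight bonds along the chain from a double-bonded nitrogen. This removes six chain carbons from the far end of the alkyl chain. Among the compounds with values here, the only step that bears on it is a 2.9-fold lower number from compound 2 to compound 3 (0.46 log units; beyond the scatter), where gaining chain length lowered the number by a modest amount. Cutting the chain back is expected to run the other way, giving a higher number, likely of similar modest size. Compound 4 is therefore estimated at 12000 nM, within a range of 5000 nM to 30000 nM, which corresponds to an expected step of a 2.1-fold higher number from compound 3 to compound 4 (0.31 log units; beyond the scatter).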

Compound 4, half-maximal inhibitory concentration: 4750 nM
Compound 4: middle estimate off by 2.5-fold (0.40 log units), on the high side; measured number below the stated range.
By their numbers in this assay, from the lowest: compound 1; then compounds 4 and 3 (each within the scatter of the next); then compound 2.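

In this assay, removing hexyl at this place, eight bonds along the chain from a double-bonded nitrogen, gives a 1.2-fold lower number from compound 3 to compound 4 (0.09 log units; within the scatter) and so leaves the number inside the usual scatter, which shows that these six outer chain carbons can go without a readable change in this assay. Compound 4 also stands apart from compound 2 by a 3.5-fold lower number from compound 2 to compound 4 (0.55 log units; beyond the scatter) with an alkyl chain at the end that carries phenyl in compound 2, so among compounds 2, 3 and 4 the clear drop goes with an alkyl chain replacing the phenyl end, whether the chain carries the extra hexyl or not. No outside measurement is available to explain why the number stays level when the chain is shortened.

From the compounds shown here alone, whether a still shorter chain, such as a propyl in place of the chain of compound 4, would stay at this level remains open, and so does the effect of a hydroxyl or an amine at the chain end. The compounds shown also leave open what a different group in place of the benzyl would do on a chain like that of compound 4.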